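The source may hold more compounds than are shown below. What is called first, only, known or untested is meant among the compounds shown, and "the series" means these compounds.

Compound 1 `O=C1/C(=C/c2ccccc2)CCC/C1=C\c1ccccc1[N+](=O)[O-]` and compound 2 `O=C1/C(=C/c2ccc(F)cc2)CCC/C1=C\c1ccccc1[N+](=O)[O-]` share one core, and compound 3 `O=C1/C(=C/c2ccccc2)CCC/C1=C\c1ccc([N+](=O)[O-])cc1` carries the same atoms joined differently; the difference between the two cores is not broken down here. In a functional assay on HL-60 cells (Homo sapiens) for cytotoxicity, with a stated time of 24 h (a lower number here means that less compound is tolerated, a higher number that more compound is tolerated), compound 1 gives 3700 nM, and compound 2 gives 3000 nM in this assay. The change between them is fluoro in place of hydrogen on an aromatic carbon and it made a step of a 1.2-fold lower number from compound 1 to compound 2 (0.09 log units; within the scatter). Compound 3 gives 20000 nM in this assay, the highest number of the three measured compounds; its nearest neighbour is compound 1 and its furthest is compound 2, and both gaps lie beyond the scatter.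

Compound 4 `O=C1/C(=C/c2ccc(F)cc2)CCC/C1=C\c1ccc([N+](=O)[O-])cc1` is not yet measured. It differs from compound 3 by fluoro in place of hydrogen on an aromatic carbon, the same change that separated compound 1 from compound 2, at the same kind of place on the ring. Because that earlier change gave only a 1.2-fold lower number from compound 1 to compound 2 (0.09 log units; within the scatter), a step within the scatter, the step from compound 3 to compound 4 is expected to be of similar size, namely a 1.2-fold lower number from compound 3 to compound 4 (0.07 log units; within the scatter). This expectation rests on a single measured pair, so its footing is narrow, and the second core has no comparison of its own. For compound 4 the estimated value in this assay is therefore 17000 nM, with a range from 8000 nM to 36000 nM.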

Compound 4, half-maximal cytotoxic concentration: 32000 nM
Compound 4: middle estimate off by 1.9-fold (0.27 log units), on the low side; measured number inside the range.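

In this assay, the same exchange of phenyl for 4-fluorophenyl on the core of compound 3 gave a 1.6-fold higher number from compound 3 to compound 4 (0.20 log units; within the scatter). Set beside the earlier step, the two results do not differ by more than the scatter of two such steps allows: the same change on two cores in this assay, a 1.2-fold lower number (0.09 log units; within the scatter) from compound 1 to compound 2 and a 1.6-fold higher number (0.20 log units; within the scatter) from compound 3 to compound 4, 2.0-fold (0.30 log units) apart, within the scatter of two such steps This shows that, on these two cores, the change moved the number by no more than repeated measurements would be expected to, so the two cores cannot be told apart by their response to it; it does not show that the change is without effect on other cores or in other tests, as it rests on just two pairs, one for each core, in a single cell assay.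

The compounds shown leave open whether a different group in the place of the fluoro, such as a chlorine, a methoxy group, an amine or a carboxylic acid, would give steps beyond the scatter, and whether such steps would carry from one core to the other. They also leave open what a fluoro would do on the ring that carries the nitro group, since every change shown here lies on the other ring.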